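Replacing 4-cyanophenyl on a sulfonamide nitrogen

The compounds below may be only part of what the source reports. "The series", "measured", "known", "first", "only" and "open" are said of these compounds alone.

Three sulfonamides sharing one core have been measured in a physicochemical assay for lipophilicity, at pH 7.4; on this read-out higher numbers stand for higher lipophilicity and lower numbers for lower lipophilicity. Compound 1 (`O=S(=O)(Nc1ccccc1C(F)(F)F)c1ccc2c(c1)C(O)CC(C1CCOCC1)O2`) gives 2.41, and compound 2 (`Cc1cc(C(O)(C(F)(F)F)C(F)(F)F)ccc1N(CC(C)C)S(=O)(=O)c1ccc2c(c1)C(O)CC(C1CCOCC1)O2`) gives 4.37. Compound 3 (`CC(C)CN(c1ccc(C#N)cc1)S(=O)(=O)c1ccc2c(c1)C(O)CC(C1CCOCC1)O2`) gives 3.07, the middle of the three numbers. It lies closer to compound 1 than to compound 2, and its gaps to both are beyond the scatter.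

Compound 4 (`CC(C)CN(C1CCc2ccc(F)cc21)S(=O)(=O)c1ccc2c(c1)C(O)CC(C1CCOCC1)O2`) has not yet been measured. It carries 6-fluoro-2,3-dihydro-1H-inden-1-yl in place of 4-cyanophenyl on a sulfonamide nitrogen. Among the compounds with values here, no two measured compounds differ in one place only, so the data offer no direct guide to the size of this step. Starting from compound 3 at 3.07, the entering group, with more heavy atoms and no hydrogen-bond acceptor, leads to the expectation of a rise beyond the scatter in this assay. The expected step is a number 0.83 log units higher from compound 3 to compound 4 (beyond the scatter). Compound 4 is estimated at 3.9, with an expected range from 3.4 to 4.4.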

Compound 4, distribution coefficient: 3.94
Beside the measured number, compound 4's estimate is 0.04 log units below it, within the range that was stated.
By their numbers in this assay, from the lowest: compound 1; then compound 3; then compound 4; then compound 2.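

One pair in this set now differs in one place only, which gives the sulfonamide nitrogen bearing the saturated chain its first direct measure of change. In this assay, 6-fluoro-2,3-dihydro-1H-inden-1-yl in place of 4-cyanophenyl gives a number 0.87 log units higher from compound 3 to compound 4 (beyond the scatter) at this place, so the read-out does respond to an exchange of the group there. Nothing measured here bears on the reason for this step.

The exchange removes the nitrile, adds a five-membered non-aromatic ring and brings in a fluorine all at once, and the compounds shown do not separate these parts. Also open, on these data alone, is where an unsubstituted phenyl, an amine or a carboxylic acid at this place would fall on this read-out, and whether the step would hold with a different chain on the same nitrogen.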